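Hydroxy for hydroxymethyl on an ester-bearing thiazole core

The source may hold more compounds than are shown below. What is called first, only, known or untested is meant among the compounds shown, and "the series" means these compounds.

Measured compounds:
compound 1, `O=C(c1sc(-c2cccc(F)c2)nc1O)N1CCOC1`: 5500 nM
compound 2, `CCOC(=O)c1sc(-c2ccccc2)nc1CO`: > 100000 nM
compound 3, `O=C(c1sc(-c2cccc(F)c2)nc1O)N1CCCCO1`: 167 nM

In an assay on HEK293 cells for inhibition of transient receptor potential cation channel subfamily M member 8 (Homo sapiens), read by FLIPR, with stated times of 5 min and 3 min (on this read-out lower numbers stand for stronger inhibition and higher numbers for weaker inhibition), compound 2 gives only a limit, > 100000 nM, and not a number; it sits at the limit of > 100000 nM in this assay, at which 1 of the 3 values shown sits. Compound 4, `CCOC(=O)c1sc(-c2ccccc2)nc1O`, has not yet been measured. It differs from compound 2 in one place: hydroxy in place of hydroxymethyl on an aromatic carbon.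

The only step shown between measured compounds is a 33-fold lower number from compound 1 to compound 3 (1.52 log units; beyond the scatter). That step changes the ring on a carbonyl carbon, not the group next to the ring nitrogen, so it says nothing direct about the change from compound 2 to compound 4. Compounds 1 and 3 carry a hydroxy group on a related core and both give numbers rather than limits in this assay, but they also differ from compound 4 elsewhere, so no firm pattern can be drawn.

Compound 4 is therefore expected, with wide uncertainty, to give 40000 nM, somewhere between 5000 nM and 150000 nM. The step of an at least 2.5-fold lower number from compound 2 to compound 4 (0.39 log units; beyond the scatter) is only an estimate, starting from a limit.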

Compound 4, half-maximal inhibitory concentration: 32 nM
Compound 4: the middle estimate sits 1300-fold (3.10 log units) above what was measured, outside the stated range (below it).
By their numbers in this assay, from the lowest: compound 4; then compound 3; then compound 1. At a limit, above all of these: compound 2.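

In this assay, this is the first step shown at the aromatic carbon next to the ring nitrogen, and the change there matters greatly: hydroxy in place of hydroxymethyl gives an at least 3100-fold lower number from compound 2 to compound 4 (3.49 log units; beyond the scatter). The reading for compound 2 is a limit and not a number: the limit of > 100000 nM in this assay, at which 1 of the 4 values shown sits. Hydroxymethyl and hydroxy have the same hydrogen-bond donor and acceptor counts and neither carries a net charge, so those counts do not separate them, and the visible difference is the one carbon that hydroxymethyl adds.

As far as these compounds go, whether an amine, a methoxy group or a carboxylic acid at this position would give a low or a high number remains open. So does whether hydroxymethyl in place of hydroxy would have a similar effect on the cores of compound 1 and compound 3.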